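Changing the Sulfonyl Aryl Group on a Low-Toxicity Series

A few compounds are considered here, and "the series" means these few. Any claim that something is new, unique, unknown or untested is made for them only; others in the source may bear on it.

Two related compounds have been examined in an ADME assay on HEK-293T cells (Homo sapiens) for inhibition, read by CCK-8 assay, with a stated time of 48 h, tested at 20 uM (on this read-out higher numbers stand for more inhibition of growth at the one concentration tested and lower numbers for less inhibition of growth), so far. Among the compounds with values here, compound 2 (`N#C/C(=C\c1ccccc1OS(=O)(=O)c1ccccc1[N+](=O)[O-])C(=O)Nc1nnc(Cc2ccccc2)s1`) gives 10% and holds the only number available in this test. Compound 1 (`N#C/C(=C\c1ccccc1OS(=O)(=O)c1ccc([N+](=O)[O-])cc1)C(=O)Nc1nnc(Cc2ccccc2)s1`) is reported as "not toxic" (no number reported) with no figure attached, so the two cannot be ranked numerically.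

The next compound to be tested is compound 3 (`N#C/C(=C\c1ccccc1OS(=O)(=O)c1ccc(Cl)cc1)C(=O)Nc1nnc(Cc2ccccc2)s1`), which carries 4-chlorophenyl in place of 2-nitrophenyl on a sulfonyl sulfur. The rest of the molecule stays as it is in compound 2.

Within the data shown here, no measured step between compounds differing in one place is available, so the size of this change has no direct precedent. A step beyond the usual scatter of this assay is not expected in either direction. This expectation rests on compound 2 at 10% and on compound 1 with its report of "not toxic" (no number reported) in the same series. The expected change is small, and the estimate amounts to a step (a number 2 percentage points higher from compound 2 to compound 3 (within the scatter)) that stays within the scatter. For compound 3 the estimated value is 12% with an expected range from 0% to 30% in this read-out.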

Compound 3, percent growth inhibition at one concentration: 25%
Beside the measured number, compound 3's estimate is 13 percentage points below it; low and high end bracket the measured number.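

In this assay, within the data shown here, the aryl group on the sulfonyl sulfur proves able to move the read-out: 4-chlorophenyl in place of 2-nitrophenyl gives a number 15 percentage points higher from compound 2 to compound 3 (beyond the scatter) and so provides the first step that can be read. Compound 1 carries the report "not toxic" (no number reported) without a figure, so the step between it and compound 3 cannot be read, even though the two differ only in the group on the sulfonyl sulfur. Nothing measured here accounts for the size of this step or explains why the exchange of these two aryl groups changes growth inhibition.

The exchange replaces 2-nitrophenyl with 4-chlorophenyl in a single move, so the compounds shown do not separate what goes with the loss of the nitro group from what goes with the arrival of the chlorine, or what goes with where each substituent sits on the ring. From the compounds shown here alone, how plain phenyl, 2-chlorophenyl or 4-methoxyphenyl on the same sulfonyl sulfur would read in this assay remains open, as does whether the higher number seen with 4-chlorophenyl would persist on any of them.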